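A few compounds are considered here, and "the series" means these few. Any claim that something is new, unique, unknown or untested is made for them only; others in the source may bear on it.

In a functional assay on the whole organism with Rattus norvegicus as the target (a lower number here means that less compound is needed, a higher number that more compound is needed for the effect), compound 1 (`CCCn1c(=N)sc2cc(OC(F)(F)F)ccc21`) gives 4.5 mg/kg. Compound 2 (`COC(=O)Cn1c(=N)sc2cc(OC(F)(F)F)ccc21`) is known only as a limit, > 10 mg/kg. Compound 3 (`N=c1sc2cc(OC(F)(F)F)ccc2n1CC(N)=O`) differs from compound 2 by amino in place of methoxy on a carbonyl carbon, with amino in place of methoxy on a carbonyl carbon. For the measured compounds named here, the only measured step, an at least 2.2-fold higher number from compound 1 to compound 2 (0.34 log units; beyond the scatter), introduced the methoxycarbonyl group, and it bears on this change only indirectly, since no measured step covers this exchange. The step expected in this assay is a number no higher from compound 2 to compound 3 (the limit leaves the size open), an estimate of no clear change beyond the scatter. For compound 3 the expected value is 10 mg/kg, with an estimated range of 4 mg/kg to 25 mg/kg.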

Compound 3, dose for half-maximal effect: 7 mg/kg
The estimate for compound 3 lay 1.4-fold (0.15 log units) above the measured number; the range from low to high includes it.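

In this assay, carbamoyl in place of ethyl on the saturated chain carbon bound to an aromatic nitrogen gives a 1.6-fold higher number from compound 1 to compound 3 (0.19 log units; within the scatter), so a carbonyl-bearing group at this place need not cost a step beyond the scatter. Amino in place of methoxy on the carbonyl carbon gives an at least 1.4-fold lower number from compound 2 to compound 3 (0.15 log units; that floor lies within the scatter), which leaves the true size of this exchange unsettled. The value of compound 2 is only a limit: the limit of > 10 mg/kg in this assay, at which 1 of the 3 values shown sits.

The compounds shown leave open how a carboxylic acid or a longer chain ending in carbamoyl would read at this place in this assay.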